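The compounds below may be only part of what the source reports. "The series", "measured", "known", "first", "only" and "open" are said of these compounds alone.

Among the measured compounds shown here, in a functional assay for inhibition of metabotropic glutamate receptor 5 (Homo sapiens), read by FLIPR and calcium flux (on this read-out higher numbers stand for weaker inhibition and lower numbers for stronger inhibition), compound 2 `Cc1cccc(C#CC(C)Sc2cccc(Cl)c2)n1` gives 118 nM, the lowest of the two numbers known so far; compound 1 `Cc1cccc(C#CCNc2cccc(Cl)c2)n1` gives 174 nM, a gap that lies within the scatter, so neither ranks above the other. Compound 3 `Cc1cccc(C#CC(Sc2cccc(Cl)c2)C(C)C)n1` has not been measured; it differs from compound 2 by isopropyl in place of methyl on a saturated chain carbon bound to a sulfur and a triple-bonded carbon. For the measured compounds named here, no step between measured compounds informs this change, so the step from compound 2 to compound 3 is expected to be small, a 1.7-fold higher number from compound 2 to compound 3 (0.23 log units; within the scatter), with no clear direction beyond the scatter. Compound 3 is therefore estimated at 200 nM, within a range of 60 nM to 700 nM.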

Compound 3, half-maximal inhibitory concentration: 461 nM
Compound 3: middle estimate off by 2.3-fold (0.36 log units), on the low side; the measured number falls inside the stated range.
By their numbers in this assay, from the lowest: compounds 2 and 1 (each within the scatter of the next); then compound 3.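

In this assay, among the compounds shown here, isopropyl in place of methyl on a saturated chain carbon bound to a sulfur and a triple-bonded carbon brings a 3.9-fold higher number from compound 2 to compound 3 (0.59 log units; beyond the scatter) and gives the first readable step at this position. It shows that inhibition here can weaken with the group on this carbon, although this single pair sets no trend. Nothing at hand explains the step.

From the compounds shown here alone, whether ethyl or a plain hydrogen on this carbon would keep the number of compound 2 remains open. So does the effect of isopropyl on the matching chain carbon bearing an amine nitrogen in place of sulfur.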